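Benzyl to tert-butyl: compound 3 to compound 4

A few compounds are considered here, and "the series" means these few. Any claim that something is new, unique, unknown or untested is made for them only; others in the source may bear on it.

Values so far in a functional assay on a cell-free system (plasma, Homo sapiens), with a stated time of 3 min; on this read-out higher numbers stand for weaker inhibition and lower numbers for stronger inhibition:
- compound 1 `Cc1cccc([C@@H](O)C(=O)N2N=CC[C@H]2C(=O)NCc2cc(Cl)ccc2-n2cnnn2)c1` gives 830 nM
- compound 2 `O=C(NCc1cc(Cl)ccc1-n1cnnn1)[C@@H]1CC=NN1C(=O)[C@H](O)c1ccccc1F` gives 1100 nM
- compound 3 `O=C(NCc1cc(Cl)ccc1-n1cnnn1)[C@@H]1CC=NN1C(=O)[C@H](O)Cc1ccccc1` gives 1400 nM

Compound 3 at 1400 nM is not separated from the other two, with a 1.3-fold higher number from compound 2 to compound 3 (0.10 log units; within the scatter) and a 1.7-fold higher number from compound 1 to compound 3 (0.23 log units; within the scatter) both inside the scatter. Among the measured compounds shown here, compound 4 `CC(C)(C)[C@@H](O)C(=O)N1N=CC[C@H]1C(=O)NCc1cc(Cl)ccc1-n1cnnn1` has tert-butyl in place of benzyl on a saturated chain carbon bound to a carbonyl carbon and an oxygen on a saturated carbon as its only change. The same place also gave a 1.3-fold higher number from compound 1 to compound 2 (0.12 log units; within the scatter) and all three steps stay small, yet each measured group carries an aromatic ring while tert-butyl has no ring. The expected step in this assay is a 1.4-fold higher number from compound 3 to compound 4 (0.15 log units; within the scatter) and so none beyond the scatter, with a slight lean to a higher number. No ringless group has been measured at this place, so the range stays wide. Compound 4 is estimated at 2000 nM with an expected range from 600 nM to 7000 nM.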

Compound 4, half-maximal inhibitory concentration: 1400 nM
Estimate against measurement, compound 4: 1.4-fold (0.15 log units) above, within the range that was stated.
By their numbers in this assay, from the lowest: compounds 1, 2, 3 and 4 (each within the scatter of the next).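

In this assay the ringless tert-butyl cannot be told apart from the aromatic groups at this place, with no change at the digits printed from compound 3 to compound 4 (within the scatter) and a 1.3-fold higher number from compound 2 to compound 4 (0.10 log units; within the scatter) and also a 1.7-fold higher number from compound 1 to compound 4 (0.23 log units; within the scatter) all within the scatter. Among these four compounds, an aromatic ring at this place is therefore not needed for a value in this range. Nothing available bears on why these groups read alike.

Still open, on these data alone, is whether an amine, a carboxylic acid or a longer chain at this place would stay in the same range or move beyond the scatter.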